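Efficacy series around compound 1: swap on the carbonyl-bound ring

The source may report more compounds than this note shows. Statements on the series, on what has been measured and on what is new or still open speak of the compounds shown alone.

Compound 1 `Cc1cc(C(=O)NCN2CCC(c3cccc[n+]3[O-])CC2)ccc1F` is the reference point for this step. In a functional assay on HEK293 cells for agonist activity at D(4) dopamine receptor (Homo sapiens), read by FLIPR (a higher number here means a larger maximal response, a lower number a smaller maximal response), compound 1 gives 67%. Of the three values at hand, compound 1 stands second highest: compound 3 `O=C(CN1CCC(c2cccc[n+]2[O-])CC1)Nc1cccc(-c2ccccc2)c1` gives 75%, and this value and that of compound 1 lie within the scatter of each other; compound 2 `Cc1cccc(NC(=O)CN2CCC(c3cccc(F)c3)CC2)c1` gives 40%, a value beyond the scatter below compound 1. Going by the values given here, compounds 2 and 3 differ from compound 1 in several places at once, so their values show only the spread of the series and no single-change step.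

Compound 4 `Cc1cc(C)cc(C(=O)NCN2CCC(c3cccc[n+]3[O-])CC2)c1` is not yet measured. It differs from compound 1 in one place: 3,5-dimethylphenyl in place of 4-fluoro-3-methylphenyl on a carbonyl carbon. Among the compounds with values here, no measured pair shows this change on its own. Both rings carry no donors or acceptors and have the same count of heavy atoms, so in this assay the step is expected to be small, in either direction, and probably not beyond the scatter. The step from compound 1 to compound 4 is estimated at a number 5 percentage points lower from compound 1 to compound 4 (within the scatter). For compound 4 a value of 62% is expected, within a range from 40% to 84%.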

Compound 4, largest response reached (reported as efficacy), in percent of the reference or control that the assay uses: 56%
For compound 4 the middle estimate is 6 percentage points above the measured one, and the stated range covers the measured number.
By their numbers in this assay, from the lowest: compound 2; then compound 4; then compounds 1 and 3 (each within the scatter of the next).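

First single-change step in the series: in this assay, the swap of 4-fluoro-3-methylphenyl for 3,5-dimethylphenyl on a carbonyl carbon gives a number 11 percentage points lower from compound 1 to compound 4 (beyond the scatter), so the maximal response is modestly sensitive to the ring at this position. The two rings match in heavy-atom count, hydrogen-bond donors and acceptors, and net charge, so those counts alone do not predict the response here. Nothing at hand explains the drop.

Because the swap removes the fluorine and alters the methyl pattern together, these compounds do not separate the two changes. Going by these compounds, how this position responds to a different kind of group, such as an amine or a carboxylic acid on the ring, also remains open.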